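The compounds below may be only part of what the source reports. "The series", "measured", "known", "first", "only" and "open" are said of these compounds alone.

Compound 2 `Nc1nn(Cc2cn(CC(=O)Nc3ccc(F)cc3)nn2)c2nc(-c3ccccc3)cc(C(F)(F)F)c12` is the reference point of this account. Within the data shown here, in a functional assay on HL-60 cells (Homo sapiens) for cytotoxicity, read by MTT assay, with a stated time of 24 h (on this read-out higher numbers stand for weaker inhibition and lower numbers for stronger inhibition), compound 2 gives 44.8 ug/mL, the lowest of the two numbers so far recorded. Its nearest neighbour is compound 1 `Nc1nn(Cc2cn(CCC(F)(F)C(F)(F)C(F)(F)C(F)(F)C(F)(F)C(F)(F)F)nn2)c2nc(-c3ccccc3)cc(C(F)(F)F)c12`, which in this assay gives 97.6 ug/mL, a higher number, and the gap between the two lies beyond the scatter. Among the measured compounds shown here, compound 1 and compound 2 differ in more than one place, so their two values show only that compound 2 sits at the lower number, and nothing about any single change.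

Compound 3 `Nc1nn(Cc2cn(CC(=O)Nc3ccc(F)cc3Br)nn2)c2nc(-c3ccccc3)cc(C(F)(F)F)c12` has not yet been measured. It differs from compound 2 in a single place: bromo in place of hydrogen on an aromatic carbon. For the measured compounds named here, no measured pair in this set carries a change of the same kind, so there is no step to lean on. The expected step is a 1.1-fold lower number from compound 2 to compound 3 (0.05 log units; within the scatter), a small one, in either direction, or none beyond the scatter. Compound 3 is therefore estimated at 40 ug/mL in this assay, with a range from 15 ug/mL to 100 ug/mL.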

Compound 3, half-maximal inhibitory concentration: 63.7 ug/mL
Estimate against measurement, compound 3: 1.6-fold (0.20 log units) below; the range from low to high includes it.
By their numbers in this assay, from the lowest: compounds 2, 3 and 1 (each within the scatter of the next, the first and the last beyond it).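

Among these compounds, the step in this assay is a 1.4-fold higher number from compound 2 to compound 3 (0.15 log units; within the scatter), and it is the first in this set that isolates a single change. It shows that bromo can stand on this aromatic carbon, ortho to a large group and meta to the fluoro group, without moving the number beyond the usual scatter, so the 2-bromo-4-fluorophenyl group and the 4-fluorophenyl group cannot be told apart in this read-out. Compounds 1 and 2 could not show this, since they differ in more than one place, and nothing available here bears on why this change has so small an effect.

The compounds shown leave open whether this carbon responds in the same way to anything other than bromo, such as chloro, a methoxy group, an amine or a carboxylic acid. They also leave open whether bromo on another carbon of the same ring, or a second bromo alongside the first, would give a step beyond the scatter.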